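Amide nitrogen substituent in the side-chain amide series

A few compounds are considered here, and "the series" means these few. Any claim that something is new, unique, unknown or untested is made for them only; others in the source may bear on it.

In an assay for inhibition of RAC-alpha serine/threonine-protein kinase (Homo sapiens), read by HTRF, with a stated time of 1 h (on this read-out lower numbers stand for stronger inhibition and higher numbers for weaker inhibition), compound 2 `Cn1ncc(Cl)c1-c1cc(C(=O)N[C@@H]2CN[C@H](CC(=O)NC3CCC3)C[C@H]2c2ccc(Cl)c(Cl)c2)oc1Cl` gives 7.98 nM, the higher of the two numbers recorded so far; compound 1 `Cn1ncc(Cl)c1-c1cc(C(=O)N[C@@H]2CN[C@H](CC(N)=O)C[C@H]2c2ccc(Cl)c(Cl)c2)oc1Cl` gives 3.24 nM. Compound 3 `CNC(=O)C[C@@H]1C[C@@H](c2ccc(Cl)c(Cl)c2)[C@H](NC(=O)c2cc(-c3c(Cl)cnn3C)c(Cl)o2)CN1` carries methyl in place of cyclobutyl on an amide-type nitrogen. Going by the values given here, the only step bearing on it is a 2.5-fold higher number from compound 1 to compound 2 (0.39 log units; beyond the scatter), which points the opposite way from the present change, since methyl lies between hydrogen and cyclobutyl in size. Compound 3 is therefore expected to land between the two measured values, with the step of a 1.6-fold lower number from compound 2 to compound 3 (0.20 log units; within the scatter) estimated as a modest fall toward compound 1. The estimate for compound 3 is 5 nM, with a range from 2 nM to 12 nM.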

Compound 3, half-maximal inhibitory concentration: 2.64 nM
Compound 3: middle estimate off by 1.9-fold (0.28 log units), on the high side, within the range that was stated.
By their numbers in this assay, from the lowest: compounds 3 and 1 (each within the scatter of the next); then compound 2.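

Methyl in place of cyclobutyl on the amide-type nitrogen gives a 3.0-fold lower number from compound 2 to compound 3 (0.48 log units; beyond the scatter) and so removes the penalty seen with cyclobutyl. Methyl in place of hydrogen at the same nitrogen gives a 1.2-fold lower number from compound 1 to compound 3 (0.09 log units; within the scatter) and so shows that this nitrogen tolerates a small substituent, at least when that substituent is methyl. No supporting data explain why cyclobutyl and methyl differ here.

Open, from the compounds shown here alone, is whether ethyl or isopropyl on this nitrogen stays with methyl or moves toward cyclobutyl. Also open, going by these compounds, is how a second methyl on the same nitrogen would read.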